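The source may report more compounds than this note shows. Statements on the series, on what has been measured and on what is new or still open speak of the compounds shown alone.

Values in a functional assay with Homo sapiens as the target; on this read-out higher numbers stand for weaker inhibition and lower numbers for stronger inhibition:
- compound 1 `CC(C)[C@H](NC(=O)COc1cccc2ccccc12)C(=O)N[C@@H](CC(=O)O)C(=O)COC(=O)c1c(Cl)cccc1Cl`: 11500 nM
- compound 2 `CC(C)[C@H](NC(=O)COc1cccc2ccccc12)C(=O)N[C@@H](CC(=O)O)C(=O)COc1ccc2ccccc2c1`: 15900 nM
- compound 3 `CC(C)[C@H](NC(=O)COc1cccc2ccccc12)C(=O)N[C@@H](CC(=O)O)C(=O)COc1ccc(C(F)(F)F)cc1`: 12300 nM

Compound 3, at 12300 nM, cannot be separated from the other two compounds, since all three values lie within the scatter of one another. The next structure is compound 4 `CC(C)[C@H](NC(=O)COc1cccc2ccccc12)C(=O)N[C@@H](CC(=O)O)C(=O)COc1ccc(F)cc1`, which carries fluoro in place of trifluoromethyl on an aromatic carbon, para to a large group: fluoro in place of trifluoromethyl on an aromatic carbon.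

Among the compounds with values here, no measured step covers this exact exchange. The nearest evidence is the set of exchanges of the whole group on the same oxygen: a 1.1-fold higher number from compound 1 to compound 3 (0.03 log units; within the scatter), a 1.3-fold lower number from compound 2 to compound 3 (0.11 log units; within the scatter) and a 1.4-fold higher number from compound 1 to compound 2 (0.14 log units; within the scatter). All three stayed within the scatter, so a smaller edit on the aromatic ring of compound 3 is not expected to produce a step beyond it in this assay, and no direction is favoured.

The estimated step is a 1.1-fold higher number from compound 3 to compound 4 (0.02 log units; within the scatter). For compound 4 the expected value is 13000 nM, with an estimated range of 7500 nM to 22000 nM.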

Compound 4, half-maximal inhibitory concentration: 14300 nM
Estimate against measurement, compound 4: 1.1-fold (0.04 log units) below, and the stated range covers the measured number.
By their numbers in this assay, from the lowest: compounds 1, 3, 4 and 2 (each within the scatter of the next).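

Cutting trifluoromethyl down to fluoro on an aromatic carbon, para to a large group, is the first edit confined to a substituent on the ring rather than to the whole group on the oxygen, and it gives a 1.2-fold higher number from compound 3 to compound 4 (0.07 log units; within the scatter) in this assay without separating the pair. The whole-group exchanges behave alike, with a 1.1-fold lower number from compound 2 to compound 4 (0.05 log units; within the scatter) and a 1.2-fold higher number from compound 1 to compound 4 (0.09 log units; within the scatter) as the remaining comparisons, so 4-fluorophenyl adds a fourth group at this site that cannot be told apart from the others. No measurement on hand accounts for this flat response.

From the compounds shown here alone, whether an amine or a sulfonamide on this ring would move the value beyond the scatter stays open. The compounds shown also cannot say what at this position would give clearly stronger inhibition.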